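Isopropyl for methyl on the biaryl of compound 2

This account rests on a few compounds, and the source may have more. Where it says the series, first, only, none or still open, it means among the compounds named here.

Measured compounds:
compound 1, `Cc1cc(OCC2CC2)cc(C)c1-c1cccc(COc2ccc(S(=O)(=O)CC(=O)O)cc2)c1`, 79.4 nM
compound 2, `Cc1ccccc1-c1cccc(COc2ccc(S(=O)(=O)CC(=O)O)cc2)c1`, 46.8 nM

Both compounds were tested in a functional assay on CHO cells for agonist activity at Free fatty acid receptor 1 (Homo sapiens), read by FLIPR and calcium flux; a higher number here means that more compound is needed for the effect, a lower number that less compound is needed. Compound 2 gives 46.8 nM, and compound 1 gives 79.4 nM; the two numbers lie within the usual scatter of each other, so neither compound can be set apart from the other on these data. Among the measured compounds shown here, compound 1 and compound 2 differ in more than one place, so no single step between them is counted.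

Compound 3, `CC(C)c1ccccc1-c1cccc(COc2ccc(S(=O)(=O)CC(=O)O)cc2)c1`, has not yet been measured in this assay. It differs from compound 2 by a single change: isopropyl in place of methyl on an aromatic carbon. For the measured compounds named here, no step of this kind between measured compounds is available, so the expectation rests on the two numbers alone and on the change itself. Given that compound 1, which carries two methyl groups and a further substituent on the same ring, gives 79.4 nM close to compound 2, a small step is expected: the estimated step of a 1.3-fold higher number from compound 2 to compound 3 (0.11 log units; within the scatter) is expected to stay near or within the scatter, with no clear direction. Compound 3 is therefore estimated at 60 nM, with a range from 20 nM to 180 nM.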

Compound 3, half-maximal effective concentration: 74.1 nM
For compound 3 the middle estimate is 1.2-fold (0.09 log units) below the measured one, and the stated range covers the measured number.
By their numbers in this assay, from the lowest: compounds 2, 3 and 1 (each within the scatter of the next).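

Among the compounds shown here, the step between these two compounds is the first single change that can be read at this place: in this assay, a 1.6-fold higher number from compound 2 to compound 3 (0.20 log units; within the scatter). Isopropyl in place of methyl on an aromatic carbon, ortho to a large group, therefore does not set compound 3 apart from compound 2, even though the entering group has three heavy atoms where the leaving group has one. Compound 1 could not show this, since it differs from compound 2 in more than one place, and no measurement shown here offers an explanation for the result.

Only methyl and isopropyl can be compared at this place, so the compounds shown leave open whether a longer chain such as n-butyl, an amine or a carboxylic acid would also stay within the scatter or would move the number clearly. For the compounds shown here, they also leave open what the cyclopropylmethoxy group and the additional methyl of compound 1 each contribute, as no single step separates either of them.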